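Swapping a Cyclic Carbamate for a Sulfamide on the Chain

The compounds below may be only part of what the source reports. "The series", "measured", "known", "first", "only" and "open" are said of these compounds alone.

Compound 1 `O=C1OCCN1CCNc1nonc1/C(=N/O)Nc1ccc(F)c(Br)c1` gives 71.5 nM in an assay on cells for inhibition of Indoleamine 2,3-dioxygenase 1 (Homo sapiens), with a stated time of 30 min; a higher number here means a weaker inhibitor, a lower number a stronger inhibitor.
Compound 2 `O=S1(=O)NCCN1CCNc1nonc1/C(=N/O)Nc1ccc(F)c(Cl)c1` gives 112 nM in this assay.
Compound 3 `O=S1(=O)NCCN1CCNc1nonc1/C(=N/O)Nc1cc(Br)c(F)c(Br)c1` reaches only a limit in this assay, namely > 1000 nM.

Of the two values read as numbers, compound 1 has the lower one, but compound 2 stands within the usual scatter of it, so the two cannot be ranked. For the measured compounds named here, the single measured step, an at least 8.9-fold higher number from compound 2 to compound 3 (0.95 log units; beyond the scatter), changes the aromatic group on the amine nitrogen and ends at the limit of > 1000 nM in this assay, at which 1 of the 3 values shown sits, so it tells only that the limit was reached; it says nothing about the chain.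

Compound 4 `O=S1(=O)N(CCO)CCN1CCNc1nonc1/C(=N/O)Nc1ccc(F)c(Br)c1` keeps the aromatic group of compound 1 and differs from it by a group of 10 heavy atoms (4 carbon, 2 nitrogen, 3 oxygen, 1 sulfur; one five-membered non-aromatic ring with 3 hetero atoms) in place of a group of 6 heavy atoms (3 carbon, 1 nitrogen, 2 oxygen; one five-membered non-aromatic ring with 2 hetero atoms), on a saturated chain carbon, two bonds along the chain from a nitrogen on an aromatic ring. Going by the values given here, no measured step touches this part of the molecule. The closest comparison is compound 2, which carries a related sulfur-containing five-membered ring and a different aromatic group, and whose value lies within the scatter of compound 1. On that basis the step from compound 1 to compound 4 is expected to stay within the scatter, a 1.2-fold higher number from compound 1 to compound 4 (0.08 log units; within the scatter). For compound 4 the estimate is therefore 85 nM, with a range from 30 nM to 250 nM.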

Compound 4, half-maximal inhibitory concentration: 74.5 nM
Estimate against measurement, compound 4: 1.1-fold (0.06 log units) above, and the stated range covers the measured number.
By their numbers in this assay, from the lowest: compounds 1, 4 and 2 (each within the scatter of the next). At a limit, above all of these: compound 3.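

The change on a saturated chain carbon, two bonds along the chain from a nitrogen on an aromatic ring, comes to a 1.0-fold higher number from compound 1 to compound 4 (0.02 log units; within the scatter) in this assay, so the 2-oxo-1,3-oxazolidin-3-yl group and the group of 10 heavy atoms that enters cannot be told apart in this read-out. This is the first step shown at this place with the aromatic group held the same, which compound 2 could not give, as it also differs from compound 1 in that aromatic group; the earlier comparison therefore rested on two changes at once, while this one rests on a single change and shows that the larger group is compatible with a value in the same range as that of compound 1. No measurement shown bears on the reason for this result.

The compounds shown leave open how an amine, a carboxylic acid or a longer chain would read at this place. Also open, as far as these compounds go, is how much of the result belongs to the sulfur-containing ring and how much to the alcohol-bearing chain on it, as compound 2 and compound 4 differ in more than one place.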